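A few compounds are considered here, and "the series" means these few. Any claim that something is new, unique, unknown or untested is made for them only; others in the source may bear on it.

Measured so far: compound 1 `Cc1cc(NCc2ccccn2)n2ncc(-c3ccc(F)cc3)c2n1` and compound 2 `Cc1cc(NCc2ccccn2)n2ncc(-c3ccccc3C)c2n1` in a physicochemical assay for solubility, read by HPLC, using the shake flask method, measured as kinetic solubility, with a stated time of 2 h, at pH 7.4; a higher number here means a more soluble compound, a lower number a less soluble compound.

In this assay compound 1 gives < 5000 nM, which is a limit of the assay. In this assay compound 2 gives < 5000 nM, again a limit and not a number. Going by the values given here, the only measured step, a step that the two limits leave unreadable from compound 1 to compound 2, is therefore of unknown size, and compound 2 stands at the limit of < 5000 nM in this assay, at which 2 of the 2 values shown sit. Among the compounds with values here, compound 3 `Cc1cc(NCc2ccccn2)n2ncc(-c3c(C)cccc3C)c2n1` differs from compound 2 by methyl in place of hydrogen on an aromatic carbon; no measured step reads on this change. Compound 3 is expected to remain at the limit, estimated at 1500 nM with a range from 300 nM to 5000 nM. The expected step from compound 2 to compound 3 is a step that the limit leaves unreadable from compound 2 to compound 3.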

Compound 3, solubility: < 5000 nM
Compound 3 ended at the assay's limit (the forecaster's own chance of this, stated with the estimate: 85%); the middle value lies beyond the limit too.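

No new step can be read in this assay, since compound 1, compound 2 and compound 3 all stand at the same limit: the limit of < 5000 nM in this assay, at which 3 of the 3 values shown sit.

The compounds shown leave open how far each lies from that limit, and whether these aromatic groups differ in solubility at all.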